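A few compounds are considered here, and "the series" means these few. Any claim that something is new, unique, unknown or untested is made for them only; others in the source may bear on it.

Values so far in a functional assay on OVCAR-5 cells (Homo sapiens) for inhibition, with a stated time of 48 h, tested at 50 uM (a lower number here means less inhibition of growth, a higher number more inhibition of growth at the concentration tested), stand as follows.
- Compound 1 `COc1ccccc1/C=C/[C@@](C)(/C=C/c1ccc(O)cc1)CCC=C(C)C` gives 38%
- Compound 2 `COc1ccc(/C=C/[C@@](C)(/C=C/c2ccc(O)cc2)CCC=C(C)C)cc1` gives 20%
- Compound 3 `COc1ccc(/C=C/[C@@](C)(/C=C/c2ccc(O)cc2)CCC=C(C)C)cc1C=O` gives 33%

Compound 2 is the lowest of the three. Next comes compound 4 `CC(C)=CCCC(C)(/C=C/c1ccc(O)cc1)/C=C/c1ccc(O)cc1` with hydrogen in place of methyl on an oxygen on an aromatic ring as its change, hydrogen in place of methyl on an oxygen on an aromatic ring. Among the measured compounds shown here, no measured step covers this change directly. The nearest evidence is two modest steps beyond the scatter, a number 18 percentage points lower from compound 1 to compound 2 (beyond the scatter) and a number 13 percentage points higher from compound 2 to compound 3 (beyond the scatter) and in both compound 2 is the lower partner. A modest rise is therefore expected, not a fall. For compound 4 the expected step is a number 8 percentage points higher from compound 2 to compound 4 (within the scatter) and it may stay within the scatter. Compound 4 is estimated at 28% with an expected range from 14% to 44% in this assay when measured.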

Compound 4, percent growth inhibition at one concentration: 33%
Beside the measured number, compound 4's estimate is 5 percentage points below it; the measured number falls inside the stated range.
By their numbers in this assay, from the lowest: compound 2; then compounds 3, 4 and 1 (each within the scatter of the next).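

In this assay, among the compounds shown here, hydrogen in place of methyl on an oxygen on an aromatic ring gives a number 13 percentage points higher from compound 2 to compound 4 (beyond the scatter) as the first reading of this change at this position; the earlier steps covered only the methoxyphenyl swap and the added formyl. The methyl on this oxygen is therefore not required for the growth inhibition seen at the concentration tested. No measurement at hand accounts for the rise. Open, as far as these compounds go, is how an ethyl or acetyl on that oxygen, or an amine in its place, would read in this assay.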